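Swapping dimethylamino for trifluoromethyl in compound 3

This account rests on a few compounds, and the source may have more. Where it says the series, first, only, none or still open, it means among the compounds named here.

Among the measured compounds shown here, in a functional assay on HCT-15 cells (Homo sapiens) for cytotoxicity, read by MTT assay, with a stated time of 2 days (on this read-out higher numbers stand for weaker inhibition and lower numbers for stronger inhibition), compound 3 (`CCN(CC)c1ccc2nc(-c3ccccc3N(C)C)[nH]c(=O)c2c1`) gives 4200 nM and so holds the higher of the two true numbers so far. Compound 2 (`CCN(CC)c1ccc2nc(-c3ccccc3OC(F)(F)F)[nH]c(=O)c2c1`) gives 1710 nM on the same scale. For the measured compounds named here, the one measured step that bears on the next compound is a 2.5-fold higher number from compound 2 to compound 3 (0.39 log units; beyond the scatter) and it is modest, with dimethylamino in place of trifluoromethoxy on an aromatic carbon. Compound 1 (`Cc1ccc2nc(-c3ccccc3C(F)(F)F)[nH]c(=O)c2c1`) also carries trifluoromethyl on a different core, and its > 50000 nM is a limit and not a number, so it gives no step size. Going by the values given here, compound 4 (`CCN(CC)c1ccc2nc(-c3ccccc3C(F)(F)F)[nH]c(=O)c2c1`) keeps the rest of compound 3 and has trifluoromethyl in place of dimethylamino on an aromatic carbon as its single change. The nearest guide is the fluorine-bearing trifluoromethoxy of compound 2, so a modest move back toward a lower number is expected, about the size of a 2.5-fold higher number from compound 2 to compound 3 (0.39 log units; beyond the scatter) but reversed. The estimated change is a 2.2-fold lower number from compound 3 to compound 4 (0.34 log units; beyond the scatter) in this assay and remains uncertain. For compound 4 the expected value is 1900 nM within an estimated range of 600 nM to 6000 nM as the likely span.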

Compound 4, half-maximal inhibitory concentration: 280 nM
For compound 4 the middle estimate is 6.8-fold (0.83 log units) above the measured one; measured number outside the range, below it.
By their numbers in this assay, from the lowest: compound 4; then compound 2; then compound 3. At a limit, above all of these: compound 1.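

In this assay this aromatic carbon, ortho to a large group, proves far more sensitive than the earlier pair suggested, with a 15-fold lower number from compound 3 to compound 4 (1.18 log units; beyond the scatter) for trifluoromethyl in place of dimethylamino. Two fluorine-bearing groups also part ways here, with a 6.1-fold lower number from compound 2 to compound 4 (0.79 log units; beyond the scatter) for trifluoromethyl in place of trifluoromethoxy, so the fluorine atoms alone do not set the number. With trifluoromethyl held fixed, diethylamino in place of methyl on an aromatic carbon of the core gives an at least 170-fold lower number from compound 1 to compound 4 (2.25 log units; beyond the scatter) as a step read against a limit and not against a number: the limit of > 50000 nM in this assay, at which 1 of the 4 values shown sits.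

On these data alone, how a chlorine atom, a nitrile or a carboxylic acid would fare on this same carbon remains open. The compounds shown also leave open whether a shorter chain such as dimethylamino, or a ring amine such as morpholine, could stand in for diethylamino on the core.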